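Swapping the aryl group on the thiadiazole core

This account rests on a few compounds, and the source may have more. Where it says the series, first, only, none or still open, it means among the compounds named here.

Measured compounds:
compound 1 `C/C(CC(=O)Nc1nnc(-c2ccc(O)cc2)s1)=N\c1ccc([N+](=O)[O-])cn1` gives 3.34
compound 2 `C/C(CC(=O)Nc1nnc(/C=C/c2ccccc2)s1)=N\c1ccc([N+](=O)[O-])cn1` gives 4.13
compound 3 `CC(=O)Oc1ccccc1-c1nnc(NC(=O)C/C(C)=N/c2ccc([N+](=O)[O-])cn2)s1` gives 3.56

In a physicochemical assay for lipophilicity, measured as octanol-water partition (on this read-out lower numbers stand for lower lipophilicity and higher numbers for higher lipophilicity), compound 3 stands second highest of the three: near compound 1, from which the step of a number 0.22 log units higher from compound 1 to compound 3 (within the scatter) lies within the scatter, and below compound 2, from which a number 0.57 log units lower from compound 2 to compound 3 (beyond the scatter) is beyond it. Compound 4 `C/C(CC(=O)Nc1nnc(-c2ccc([N+](=O)[O-])cc2)s1)=N\c1ccc([N+](=O)[O-])cn1` differs from compound 3 by 4-nitrophenyl in place of 2-acetoxyphenyl on an aromatic carbon. Within the data shown here, no measured step introduces 4-nitrophenyl, so only the two steps that involve 2-acetoxyphenyl bear on the change, and both were small to modest. A small shift upward in this assay, at most around the edge of the scatter, is therefore expected, a number 0.24 log units higher from compound 3 to compound 4 (within the scatter). Compound 4 is estimated at 3.8, with a range from 3.4 to 4.2.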

Compound 4, partition coefficient: 3.54
Compound 4: middle estimate off by 0.26 log units, on the high side; low and high end bracket the measured number.
By their numbers in this assay, from the lowest: compounds 1, 4 and 3 (each within the scatter of the next); then compound 2.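

In this assay, 4-nitrophenyl on this aromatic carbon reads like the other two substituted phenyl groups (a number 0.02 log units lower from compound 3 to compound 4 (within the scatter); a number 0.20 log units higher from compound 1 to compound 4 (within the scatter)), so compounds 1, 3 and 4 cannot be told apart. Only 2-phenylethenyl stands apart (a number 0.59 log units lower from compound 2 to compound 4 (beyond the scatter)). No measurement at hand accounts for this. As far as these compounds go, whether that gap belongs to the ethenyl link or to the unsubstituted phenyl ring stays open. So does how an amine or a carboxylic acid on the phenyl ring would read.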